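Shortening a Carboxylic Acid Chain on Two Related Cores

A few compounds are considered here, and "the series" means these few. Any claim that something is new, unique, unknown or untested is made for them only; others in the source may bear on it.

Of the compounds shown here, three have been measured in an assay on HEK293 cells for inhibition of solute carrier family 22 member 12 (Homo sapiens), read by scintillation counting, with stated times of 30 min and 15 min; on this read-out higher numbers stand for weaker inhibition and lower numbers for stronger inhibition. Compound 1 `N#Cc1ccc(Oc2cnccc2SCCCCC(=O)O)c2ccccc12` gives 4220 nM in this assay. Compound 2 `N#Cc1ccc(Oc2cnccc2SCCCCCCC(=O)O)c2ccccc12` gives 3780 nM in this assay. Compound 3 `CN(c1cnccc1SCCCCCC(=O)O)c1ccc(C#N)c2ccccc12`, which carries a different core, gives 3760 nM in this assay. The difference between the core of compound 3 and the core of compound 2 is not broken down here; their two values lie within the scatter of each other.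

Between compound 2 and compound 1 the chain bearing the acid is cut short: carboxy in place of 2-carboxyethyl on a saturated chain carbon, four bonds along the chain from a sulfur. The step it made is a 1.1-fold higher number from compound 2 to compound 1 (0.05 log units; within the scatter).

Compound 4 `CN(c1cnccc1SCCCC(=O)O)c1ccc(C#N)c2ccccc12` has not yet been measured in this assay. It arises from compound 3 by the same kind of change, (carboxy in place of 2-carboxyethyl on a saturated chain carbon, three bonds along the chain from a sulfur). The place is not identical, since the acid sits three bonds along the chain from the sulfur in compound 4, where in compound 1 it sits four bonds along the chain from the sulfur.

The expectation for compound 4 rests on compound 3, whose value is 3760 nM, and on the shortening seen in the earlier pair, which gave a 1.1-fold higher number from compound 2 to compound 1 (0.05 log units; within the scatter). On that basis the step from compound 3 to compound 4 is estimated as a 1.1-fold higher number from compound 3 to compound 4 (0.06 log units; within the scatter). Compound 4 is therefore expected to give about 4300 nM in this assay, estimated to lie between 1500 nM and 12000 nM.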

Compound 4, half-maximal inhibitory concentration: 2580 nM
For compound 4 the middle estimate is 1.7-fold (0.22 log units) above the measured one, within the range that was stated.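

In this assay, the shortening of the chain on the core of compound 3 gave a 1.5-fold lower number from compound 3 to compound 4 (0.16 log units; within the scatter), so the change has no readable effect on this core, just as it had none on the core of compound 1. Set side by side, the two steps do not differ beyond what repeated measurement allows: the same change on two cores in this assay, a 1.1-fold higher number (0.05 log units; within the scatter) from compound 2 to compound 1 and a 1.5-fold lower number (0.16 log units; within the scatter) from compound 3 to compound 4, 1.6-fold (0.21 log units) apart, within the scatter of two such steps. Among the compounds shown here, this shows that, across these two pairs, the change carries from one core to the other without any sign that the core alters its outcome, but it does not show that the two cores respond alike in any stronger sense, since both steps are too small to read, only two pairs are available, and the place is not identical, with the acid sitting three bonds along the chain from the sulfur in compound 4 and four bonds along in compound 1.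

The compounds shown leave open how a still shorter chain, such as carboxymethyl, or a much longer chain would read on either core, and whether the values would hold with a tetrazole or an amide in place of the carboxylic acid. They also leave open whether the same shortening would read alike on a third core.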